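Swapping cyclobutyl for a methoxyethyl chain on an amide

The compounds below may be only part of what the source reports. "The series", "measured", "known", "first", "only" and "open" are said of these compounds alone.

Of the compounds shown here, two sharing the same core have been tested in an ADME assay on MRC5 cells (Homo sapiens) for inhibition, with a stated time of 72 h; a lower number here means that less compound is needed, a higher number that more compound is needed for the effect. Compound 1 `CCc1ccccc1C(=O)Nc1c[nH]nc1C(=O)N[C@H]1CC[C@H](OC)CC1` gives 3400 nM in this assay. Compound 2 `COc1cccc(OC)c1C(=O)Nc1c[nH]nc1C(=O)NC1CCC1` shows > 50000 nM, which is a limit of the assay rather than a measured number. Compound 2 thus stands at the limit of > 50000 nM in this assay, at which 1 of the 2 values shown sits, while compound 1 stands at a measured value. No step between two measured compounds that differ in a single place is shown, so the two values say only what each compound does on its own.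

Compound 3 `COCCNC(=O)c1n[nH]cc1NC(=O)c1c(OC)cccc1OC` has not yet been measured. It differs from compound 2 in one place: 2-methoxyethyl in place of cyclobutyl on an amide-type nitrogen. The rest of compound 2 is left untouched. Compound 2 sits at the limit, and the expected step in this assay is none beyond the usual scatter, so a step that the limit leaves unreadable from compound 2 to compound 3 is estimated to be small. Compound 3 is expected to give about 60000 nM in this assay, with a likely range from 15000 nM to 200000 nM, and a fair chance that only a limit is reported again.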

Compound 3, half-maximal effective concentration: > 50000 nM
Compound 3: no number, only a limit; the forecaster's own chance of this, stated with the estimate: 65%; the middle value is on the limit's open side.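

In this assay, compound 2 and compound 3 each give only a limit of the assay rather than a number, and no step between them can be read because of this: the limit of > 50000 nM in this assay, at which 2 of the 3 values shown sit.

From the compounds shown here alone, whether 2-methoxyethyl in place of cyclobutyl on an amide-type nitrogen changes the concentration needed at all remains open.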